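From diethylamino to amino: compound 2 and compound 4

The source may report more compounds than this note shows. Statements on the series, on what has been measured and on what is new or still open speak of the compounds shown alone.

Of the compounds shown here, three have been measured in a functional assay on HepG2 cells (Homo sapiens), read by MTT assay, with a stated time of 48 h; on this read-out higher numbers stand for weaker inhibition and lower numbers for stronger inhibition. Compound 1 `CCN(CC)CCNC(=O)c1ccc(C(CC)(CC)c2ccc(OCC(=O)C(C)(C)C)c(C)c2)n1CC` gives 620 nM. Compound 2 `CCN(CC)CCNC(=O)c1ccc(C(CC)(CC)c2ccc(OCC(O)C(C)(C)C)c(C)c2)n1CC` gives 490 nM. Compound 3 `CCn1c(C(=O)NCCN(C)C)ccc1C(CC)(CC)c1ccc(OCC(O)C(C)(C)C)c(C)c1` gives 870 nM. Compound 2 stands within the scatter of both other compounds, as the two measured steps show: a 1.3-fold lower number from compound 1 to compound 2 (0.10 log units; within the scatter) and a 1.8-fold higher number from compound 2 to compound 3 (0.25 log units; within the scatter).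

Compound 4 `CCn1c(C(=O)NCCN)ccc1C(CC)(CC)c1ccc(OCC(O)C(C)(C)C)c(C)c1` differs from compound 2 by amino in place of diethylamino on a saturated chain carbon, two bonds along the chain from an amide-type nitrogen.

The change from compound 1 to compound 2, a 1.3-fold lower number from compound 1 to compound 2 (0.10 log units; within the scatter), replaces (tert-butyl)carbonyl with 1-hydroxy-2,2-dimethylpropyl and leaves the diethylamino group untouched, so it offers no direct guide. For the measured compounds named here, compound 3 is the only measured compound with a change at this group, a 1.8-fold higher number from compound 2 to compound 3 (0.25 log units; within the scatter), and it points toward a higher number without leaving the scatter. Going by the values given here, no measured compound carries the amino group, so this expectation is an extrapolation from a single small step, and a wide range is warranted. A modest step toward a higher number is therefore expected in this assay. The step expected is a 2.2-fold higher number from compound 2 to compound 4 (0.35 log units; beyond the scatter). For compound 4 the estimated value is 1100 nM, with an expected range of 450 nM to 2800 nM.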

Compound 4, half-maximal inhibitory concentration: 176 nM
Compound 4: the middle estimate sits 6.3-fold (0.80 log units) above what was measured; the whole stated range lies above it.
By their numbers in this assay, from the lowest: compound 4; then compounds 2, 1 and 3 (each within the scatter of the next).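

In this assay, for the compounds shown here, the amino group is the first change at this end of the side chain that leaves the scatter, and it does so against both tertiary amines: (a 2.8-fold lower number from compound 2 to compound 4 (0.44 log units; beyond the scatter)) and (a 4.9-fold lower number from compound 3 to compound 4 (0.69 log units; beyond the scatter)). The earlier exchange of diethylamino for dimethylamino (a 1.8-fold higher number from compound 2 to compound 3 (0.25 log units; within the scatter)) stayed within the scatter, so that pair alone could not show that this position responds to the group it carries; compound 4 shows that it does, and that the response appears once both alkyl groups on the nitrogen are gone, with a lower number rather than the higher one the earlier step hinted at. No measurement at hand accounts for this step.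

The change removes four carbons and adds a hydrogen-bond donor at once, and these compounds cannot separate the two, since a methylamino group, which would stand between dimethylamino and amino, is not among those shown here. Also open, from the compounds shown here alone, is whether the lower number holds with a longer chain between the amide nitrogen and the amino group, or with the amino group on the ketone of compound 1.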